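This account rests on a few compounds, and the source may have more. Where it says the series, first, only, none or still open, it means among the compounds named here.

Measured in a functional assay on MDA-MB-231 cells (Homo sapiens) for antiproliferative activity, with a stated time of 4 days; on this read-out higher numbers stand for weaker inhibition and lower numbers for stronger inhibition:
- compound 1 `CCCCc1ccc2[nH]c(-c3ccc(OC)cc3)c(/C=N/NC(=O)c3ccc([N+](=O)[O-])cc3)c2c1`: 115 nM
- compound 2 `CCCCc1ccc2[nH]c(-c3ccc(OC)cc3)c(/C=N/NC(=O)c3ccncc3)c2c1`: 29 nM

Of the two, compound 2 has the lower number and so the stronger inhibition in this assay. The next compound, compound 3 `CCCCc1ccc2[nH]c(-c3ccc(OC)cc3)c(/C=N/NC(=O)c3cccnc3)c2c1`, differs from it in a single place: pyridin-3-yl in place of pyridin-4-yl on a carbonyl carbon. In words, pyridin-3-yl stands in place of pyridin-4-yl on a carbonyl carbon. Among the measured compounds shown here, only one measured step bears on this, and it is not the same exchange: a 4.0-fold lower number from compound 1 to compound 2 (0.60 log units; beyond the scatter), a modest step in which pyridin-4-yl replaced 4-nitrophenyl at that place. It shows that this place can matter, but the data hold no direct comparison of the two pyridinyl groups. A smaller step is therefore expected, probably not beyond the scatter, and leaning towards a slightly higher number. The estimated step is a 1.4-fold higher number from compound 2 to compound 3 (0.14 log units; within the scatter). Compound 3 is expected at 40 nM, within an estimated range of 15 nM to 110 nM.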

Compound 3, half-maximal inhibitory concentration: 35 nM
The estimate for compound 3 lay 1.1-fold (0.06 log units) above the measured number; the range from low to high includes it.
By their numbers in this assay, from the lowest: compounds 2 and 3 (each within the scatter of the next); then compound 1.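

In this assay, pyridin-3-yl in place of pyridin-4-yl on the carbonyl carbon gives a 1.2-fold higher number from compound 2 to compound 3 (0.08 log units; within the scatter), so the two pyridinyl groups cannot be told apart at this place. The step away from 4-nitrophenyl is therefore not tied to pyridin-4-yl alone: pyridin-3-yl in place of 4-nitrophenyl gives a 3.3-fold lower number from compound 1 to compound 3 (0.52 log units; beyond the scatter), and this step also lies beyond the scatter. Nothing measured on these compounds offers an explanation for either step.

As far as these compounds go, it remains open whether pyridin-2-yl, unsubstituted phenyl or a saturated amine such as piperidin-4-yl would fit this pattern on the carbonyl carbon. From the compounds shown here alone, it also remains open whether the pyridinyl groups would still match each other if other parts of the shared core were changed.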